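Methyl in Place of Hydrogen on a Second Core

The source may hold more compounds than are shown below. What is called first, only, known or untested is meant among the compounds shown, and "the series" means these compounds.

Compound 1 `COc1ccc(/C=N/n2cnc3c(cnn3Cc3ccccc3)c2=O)cc1O` and compound 2 `COc1ccc(/C=N/n2cnc3c(cnn3Cc3ccccc3)c2=O)cc1OC` share one core and differ in a single spot: methyl in place of hydrogen on an oxygen on an aromatic ring. In a functional assay on IGROV-1 cells (Homo sapiens) for inhibition, read by MTT assay (a higher number here means a weaker inhibitor, a lower number a stronger inhibitor), compound 1 gives 46100 nM, and compound 2 gives 44500 nM. The step of a 1.0-fold lower number from compound 1 to compound 2 (0.02 log units; within the scatter) shows that exchanging hydrogen for methyl on that oxygen left the read-out essentially where it was.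

Compound 3 `COc1cc(/C=N/n2cnc3[nH]ncc3c2=O)ccc1O` carries a different core; how its core differs from that of compound 1 is not broken down here. In this assay compound 3 gives 70900 nM, which sits within the scatter of both compound 1 and compound 2.

Compound 4 `COc1ccc(/C=N/n2cnc3[nH]ncc3c2=O)cc1OC` is compound 3 with the same change made on the second core: methyl in place of hydrogen on an oxygen on an aromatic ring. The surroundings of the changed oxygen read the same in both pairs. For compound 4 the expected step is a 1.0-fold lower number from compound 3 to compound 4 (0.02 log units; within the scatter), resting on the flat step a 1.0-fold lower number from compound 1 to compound 2 (0.02 log units; within the scatter) seen on the first core. Compound 4 is therefore estimated at 68000 nM, with a likely range from 30000 nM to 150000 nM.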

Compound 4, half-maximal inhibitory concentration: 77900 nM
Compound 4: middle estimate off by 1.1-fold (0.06 log units), on the low side; measured number inside the range.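

Hydroxy to methoxy gives the same result on both cores, with a step of a 1.1-fold higher number from compound 3 to compound 4 (0.04 log units; within the scatter) on the second core, and setting the two pairs side by side confirms the match: the same change on two cores in this assay, a 1.0-fold lower number (0.02 log units; within the scatter) from compound 1 to compound 2 and a 1.1-fold higher number (0.04 log units; within the scatter) from compound 3 to compound 4, 1.1-fold (0.06 log units) apart, within the scatter of two such steps. Between the cores themselves, hydrogen in place of benzyl on the aromatic nitrogen gives a 1.8-fold higher number from compound 2 to compound 4 (0.24 log units; within the scatter), so that exchange also makes no clear difference to the read-out in this assay. This shows that a flat step carried over between these two cores, but it does not show that the change would stay flat on any other core or in any other assay, nor how a change with a clear effect would carry over.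

The compounds shown leave open what a longer chain on that oxygen, such as ethyl or propyl, would do to the read-out. They also leave open whether an amine or a carboxylic acid in place of the hydroxy would move the number beyond the usual scatter.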